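Swapping the amide substituent on a pyrrolidine-linked pyrimidine core

The source may hold more compounds than are shown below. What is called first, only, known or untested is meant among the compounds shown, and "the series" means these compounds.

The measured compounds and their values in an assay on isolated protein for inhibition of Rho-associated protein kinase 2 (Homo sapiens), read by HTRF, tested at 10 uM; a higher number here means more inhibition at the concentration tested (going by the name of the read-out), a lower number less inhibition:

Compound 1, `CN(CCCn1ccnc1)C(=O)[C@@H]1CCCN1c1nccc(Nc2ccccc2)n1`: 1%
Compound 2, `COC[C@@H]1CCCN1C(=O)[C@@H]1CCCN1c1cc(Nc2cccc(OC)c2)nc(N)n1`: 0%
Compound 3, `COC[C@@H]1CCCN1C(=O)[C@@H]1CCCN1c1nccc(Nc2ccccc2)n1`: 3%

All three numbers sit close to zero, and none of the gaps between them goes beyond the scatter of repeated measurements. Compound 3 has the highest of the three numbers on paper, yet its nearest neighbour, compound 1, is only a number 2 percentage points higher from compound 1 to compound 3 (within the scatter), and compound 2 lies only a little further away; no ordering among them can be claimed.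

The next compound, compound 4, `CN(C)CC(C)(C)CNC(=O)[C@@H]1CCCN1c1nccc(Nc2ccccc2)n1`, differs from compound 3 in one place: (2-((dimethylamino)methyl)-2-methylpropyl)amino in place of 2-(methoxymethyl)pyrrolidin-1-yl on a carbonyl carbon. Among the compounds with values here, only one measured step bears on this position, the change from compound 1 to compound 3, and that step was within the scatter. Both substituents tried on the carbonyl carbon so far left this assay near zero, so the new substituent is not expected to move the number beyond the scatter either.

The expected step from compound 3 to compound 4 is therefore a number 1 percentage points lower from compound 3 to compound 4 (within the scatter). Compound 4 is estimated to give 2% in this assay, with a range from -8% to 12%.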

Compound 4, a percentage reported as inhibition, at one concentration (the size of the read-out at that concentration, not a potency): 0%
Compound 4: middle estimate off by 2 percentage points, on the high side; the measured number falls inside the stated range.
By their numbers in this assay, from the lowest: compounds 2, 4, 1 and 3 (each within the scatter of the next).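

In this assay, putting (2-((dimethylamino)methyl)-2-methylpropyl)amino in place of 2-(methoxymethyl)pyrrolidin-1-yl on the carbonyl carbon gives a number 3 percentage points lower from compound 3 to compound 4 (within the scatter), and putting it in place of (3-(1H-imidazol-1-yl)propyl)(methyl)amino gives a number 1 percentage points lower from compound 1 to compound 4 (within the scatter). This new group has no ring and brings one hydrogen-bond donor, whereas 2-(methoxymethyl)pyrrolidin-1-yl has a ring and no donor, so the position has now been tested with a clearly different kind of substituent, and the number still cannot be told apart from the other two. No measurement shown here offers an explanation for this flat result.

With every number this close to zero, the compounds leave open whether the group on this carbonyl carbon matters at all, or whether the rest of the shared molecule keeps the number low whatever sits there. A benzylamino group on the carbonyl carbon, or a carboxylic acid in place of the whole amide, would test whether any change here can lift the number clear of the scatter.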